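A few compounds are considered here, and "the series" means these few. Any claim that something is new, unique, unknown or untested is made for them only; others in the source may bear on it.

The study concerns analogues sharing one core, three of which have been measured in an ADME assay on CCRF-HSB-2 cells (Homo sapiens) for cytotoxicity, with a stated time of 7 days; on this read-out lower numbers stand for higher toxicity in this test and higher numbers for lower toxicity in this test. Compound 1, `Nc1nc(NC2CCCCC2)c2ncn(/C=C3/CC3(CO)CO)c2n1`, and compound 2, `Nc1nc(NC2CC2)c2ncn(/C=C3/CC3(CO)CO)c2n1`, differ in the group carried on the exocyclic nitrogen, while compound 3, `CCCCCCSc1nc(N)nc2c1ncn2/C=C1/CC1(CO)CO`, carries a hexylsulfanyl group in place of either amine. In this assay compound 1 gives only a limit, > 20000 nM. Compound 2 likewise reaches only a limit, > 20000 nM. Among the measured compounds shown here, compound 3 gives the single number of the set, 60000 nM. The step that the two limits leave unreadable from compound 1 to compound 2, the step that the limit leaves unreadable from compound 1 to compound 3 and the step that the limit leaves unreadable from compound 2 to compound 3 all remain without a readable size, which is due to the limit of > 20000 nM in this assay, at which 2 of the 3 values shown sit. Compound 4, `CN(C)c1nc(N)nc2c1ncn2/C=C1/CC1(CO)CO`, has not yet been measured; it changes compound 3 by dimethylamino in place of hexylsulfanyl on an aromatic carbon. For the measured compounds named here, no measured step therefore gives a readable size or direction for this change, and all three measured compounds sit at or beyond the limit region of this assay. On that basis the step of no change at the digits printed from compound 3 to compound 4 (within the scatter) is expected to be small. Compound 4 is estimated at 60000 nM, with a range from 20000 nM to 200000 nM, and with a fair chance that only a limit is reported.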

Compound 4, half-maximal cytotoxic concentration: > 20000 nM
Compound 4: a limit, no number; the forecaster's own chance of this, stated with the estimate: 50%; the middle value lies beyond the limit too.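

In this assay compound 4 gives only a limit, and no step linking it to compound 1, compound 2 or compound 3 can be read, due to one feature of these results: the limit of > 20000 nM in this assay, at which 3 of the 4 values shown sit.

The compounds shown leave open whether dimethylamino, cyclopropylamino, cyclohexylamino and hexylsulfanyl on the shared core differ at all in cytotoxicity.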